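Chloro in Place of Fluoro: From Compound 1 to Compound 3

The compounds below may be only part of what the source reports. "The series", "measured", "known", "first", "only" and "open" are said of these compounds alone.

Measured so far:
compound 1 `Fc1ccc(-c2csc(N/N=C/c3ccc(Cl)cc3Cl)n2)cc1`: 88.4%
compound 2 `Cc1ccc(-c2csc(N/N=C/c3cccs3)n2)cc1`: 79.6%

In a functional assay, read by spectrophotometry, with a stated time of 15 min, tested at 20 ug/mL (a lower number here means a weaker effect, a higher number a stronger effect of the compound at the concentration tested), compound 1 gives 88.4%, the highest of the two numbers shown. In this assay compound 2 gives 79.6%, a number within the scatter of compound 1, so the two cannot be ranked against each other. Compound 3 `Clc1ccc(-c2csc(N/N=C/c3ccc(Cl)cc3Cl)n2)cc1` has not been measured. Compared with compound 1 it shows (chloro in place of fluoro on an aromatic carbon). Among the measured compounds shown here, no pair of measured compounds differs in a single place, so there is no measured step to set the size of this change; the expectation therefore rests on the change itself and on the number of compound 1. The step of a number 1.4 percentage points lower from compound 1 to compound 3 (within the scatter) is expected to be small, in no clear direction, and not beyond the scatter. Compound 3 is estimated at 87%, with a range from 74% to 96%.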

Compound 3, a percentage reported as inhibition, at one concentration (the size of the read-out at that concentration, not a potency): 76%
The estimate for compound 3 lay 11 percentage points above the measured number; the range from low to high includes it.
By their numbers in this assay, from the lowest: compounds 3, 2 and 1 (each within the scatter of the next, the first and the last beyond it).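

In this assay, among the compounds shown here, the exchange of the 4-fluorophenyl for the 4-chlorophenyl gives a number 12.4 percentage points lower from compound 1 to compound 3 (beyond the scatter) and this is the first step that rests on a single change in one place. It shows that this aromatic carbon, para to a large group, does not treat fluoro and chloro as equivalent in this read-out, with fluoro giving the higher number of the two. Nothing available explains the step, and no measured property of either compound bears on it.

On these data alone, one step sets no trend, so it remains open whether a bromo, a methoxy or an amine on this same carbon would stand with fluoro, with chloro or apart from both. Also open, as far as these compounds go, is whether the same exchange would carry the same weight on a different core.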